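Ethyl added to the methylamino nitrogen of compound 2

The source may report more compounds than this note shows. Statements on the series, on what has been measured and on what is new or still open speak of the compounds shown alone.

Compound 2 `CNCc1ccc(Cl)c(-c2ccccc2OC)c1` gives 2400 nM in an assay on isolated protein for binding affinity to 5-hydroxytryptamine receptor 1E (Homo sapiens); a lower number here means a stronger inhibitor, a higher number a weaker inhibitor; compound 1 `COc1ccccc1-c1cc(C2CCN(C)C2)ccc1Cl` gives 4100 nM, and the step of a 1.7-fold lower number from compound 1 to compound 2 (0.23 log units; within the scatter) lies within the scatter, so the two stand together. Compound 3 `CCCNCc1ccc(Cl)c(-c2ccccc2OC)c1` differs from compound 2 by ethyl in place of hydrogen on a saturated chain carbon bound to an amine nitrogen. Among the measured compounds shown here, the only measured step exchanges 1-methylpyrrolidin-3-yl for (methylamino)methyl and says nothing about lengthening the chain on the amine nitrogen, so no step beyond the scatter is expected in this assay in either direction. Compound 3 is estimated at 2400 nM, with a range from 700 nM to 8000 nM. The expected step is no change at the digits printed from compound 2 to compound 3 (within the scatter).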

Compound 3, inhibition constant: > 10000 nM
Compound 3 gave a limit, no number; the forecaster's own chance of this, stated with the estimate: 5%; at least 4.1-fold (0.61 log units) between middle value and limit.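

In this assay the result for compound 3 is a limit, not a number: the limit of > 10000 nM in this assay, at which 1 of the 3 values shown sits.

Lengthening methylamino to propylamino gives an at least 4.1-fold higher number from compound 2 to compound 3 (0.61 log units; beyond the scatter), and replacing 1-methylpyrrolidin-3-yl with (propylamino)methyl gives an at least 2.4-fold higher number from compound 1 to compound 3 (0.38 log units; beyond the scatter). Among the compounds shown here, these are the first steps beyond the scatter, whereas the change from 1-methylpyrrolidin-3-yl to (methylamino)methyl stayed within it, so the chain on the amine nitrogen is a place where this assay responds.

As far as these compounds go, the true size of both steps remains open past the limit. Also open, from the compounds shown here alone, is whether a primary amine or an ethylamino group would stand with compound 2 or with compound 3.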